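Swapping a Nitrile for a Sulfonamide: Cytotoxicity Outlook

A few compounds are considered here, and "the series" means these few. Any claim that something is new, unique, unknown or untested is made for them only; others in the source may bear on it.

Compound 1, `CC1(C)C[C@H](O)C[C@](C)(CNc2nc3ccccc3s2)C1`: 36800 nM
Compound 2, `CC1(C)C[C@H](O)C[C@](C)(CNc2cccc(C#N)c2)C1`: 46900 nM

Both compounds share one core and were tested in an ADME assay on MDCK cells (Canis lupus familiaris) for cytotoxicity, read by MTT assay, with a stated time of 3 days; on this read-out lower numbers stand for higher toxicity in this test and higher numbers for lower toxicity in this test. In this assay compound 1 gives 36800 nM and compound 2 gives 46900 nM. These two numbers lie within the usual scatter of each other, so compound 2 stands alongside compound 1 rather than apart from it. On these data alone, compound 3 `CC1(C)C[C@H](O)C[C@](C)(CNc2cccc(S(N)(=O)=O)c2)C1` is untested; it differs from compound 2 by sulfamoyl in place of cyano on an aromatic carbon. Going by the values given here, no comparable step between measured compounds exists to guide the estimate, so the expected change is a 1.0-fold lower number from compound 2 to compound 3 (0.02 log units; within the scatter), nothing beyond the scatter. Compound 3 is therefore expected to give about 45000 nM, between 20000 nM and 100000 nM.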

Compound 3, half-maximal cytotoxic concentration: > 100000 nM
Compound 3 was reported as a limit; the forecaster's own chance of this, stated with the estimate: 15%; middle value at least 2.2-fold (0.34 log units) from the limit.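

Sulfamoyl in place of cyano on this aromatic carbon gives an at least 2.1-fold higher number from compound 2 to compound 3 (0.32 log units; beyond the scatter), so a change at this position can move the read-out beyond the scatter, which compound 1 and compound 2 alone could not show. Compound 3 gives > 100000 nM in this assay, which is a limit of the assay and not a number. The full size of the step stays unknown because only this limit is available: the limit of > 100000 nM in this assay, at which 1 of the 3 values shown sits.

The compounds shown leave open whether an amine or a carboxylic acid at this position would also reach that limit. They also leave open whether a methylsulfonyl group, which lacks the sulfamoyl nitrogen, would behave like sulfamoyl.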